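The compounds below may be only part of what the source reports. "The series", "measured", "known", "first", "only" and "open" are said of these compounds alone.

Measured so far in a functional assay on WI-38 VA13 cells (Homo sapiens) for cytotoxicity; on this read-out higher numbers stand for an effect only at larger amounts of compound and lower numbers for an effect already at smaller amounts:
Compound 1 `O=C(Nc1ccc2nc(NC(=O)C3CCCCC3)sc2c1)c1ccccc1Oc1ccccc1`: 0.1 ug/mL
Compound 2 `COc1ccc(C(=O)Nc2ccc3nc(NC(=O)C4CCCCC4)sc3c2)cc1`: 4.9 ug/mL

Of these two, compound 2 stands higher at 4.9 ug/mL, and compound 1 lies lower at 0.1 ug/mL, a gap well beyond the usual scatter. Compound 2 therefore needs the larger amount to show an effect in this assay.

Compound 3 `CCC(C)(C)C(=O)Nc1ccc2nc(NC(=O)C3CCCCC3)sc2c1` keeps the shared core and changes one group: 1,1-dimethylpropyl stands in place of 4-methoxyphenyl on a carbonyl carbon (1,1-dimethylpropyl in place of 4-methoxyphenyl on a carbonyl carbon). Among the compounds with values here, no measured pair shows what this exchange does, so any expectation is uncertain. With compound 2 at 4.9 ug/mL as the closest guide, no change beyond the scatter is expected, and the estimated move is a 1.2-fold lower number from compound 2 to compound 3 (0.09 log units; within the scatter). For compound 3 the estimated value is 4 ug/mL, with an expected range of 0.8 ug/mL to 15 ug/mL.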

Compound 3, half-maximal effective concentration: 1 ug/mL
Compound 3: middle estimate off by 4.0-fold (0.60 log units), on the high side; the measured number falls inside the stated range.
By their numbers in this assay, from the lowest: compound 1; then compound 3; then compound 2.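

Putting 1,1-dimethylpropyl in place of 4-methoxyphenyl on this carbonyl carbon gives a 4.9-fold lower number from compound 2 to compound 3 (0.69 log units; beyond the scatter) in this assay. This is the first single exchange shown at this place, and it shows that the group here can shift the amount of compound needed for an effect, and that a group with no ring can stand here and still give an effect at a smaller amount. The exchange removes the aromatic ring and the oxygen together and lowers the heavy-atom count, and no measurement at hand says which of these changes matters or explains the step.

On these data alone, whether a plain phenyl, with the ring kept and the methoxy group gone, would behave like compound 2 or like compound 3 remains open. So does the effect of a longer carbon chain, an amine or a carboxylic acid on this carbonyl carbon.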